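The source may report more compounds than this note shows. Statements on the series, on what has been measured and on what is new or still open speak of the compounds shown alone.

Compound 3, `COc1cc(NC(C)CCCNC(=O)NNC(=O)/C(C)=C/c2ccccc2)c2ncccc2c1`, is the middle entry of the three tested in an ADME assay on L6 cells (Rattus norvegicus) for cytotoxicity, read by resazurin assay, with a stated time of 70 h (a higher number here means a weaker inhibitor, a lower number a stronger inhibitor), where compound 3 gives 36500 nM. Compound 2, `COc1cc(NC(C)CCCNC(=O)Nc2cc(C(F)(F)F)cc(C(F)(F)F)c2)c2ncccc2c1`, gives the lowest number, 14900 nM, and compound 1, `COc1cc(NC(C)CCCNC(=O)/C=C/c2cc(C(F)(F)F)cc(C(F)(F)F)c2)c2ncccc2c1`, the highest, 158000 nM; the gaps from compound 3 to both lie beyond the scatter. Compound 4, `COc1cc(NC(C)CCCNC(=O)NNC(=O)Nc2ccc(Br)cc2)c2ncccc2c1`, is not yet measured. It differs from compound 3 by (4-bromophenyl)amino in place of 1-methyl-2-phenylethenyl on a carbonyl carbon. The two values of compound 2 and compound 1 show an aryl amide-type partner with a lower number than an unsaturated acyl one, so the step expected from compound 3 to compound 4 in this assay is a modest one downward, a 1.8-fold lower number from compound 3 to compound 4 (0.26 log units; within the scatter), near the edge of the scatter. Compound 4 is therefore estimated at 20000 nM, within 6000 nM to 60000 nM.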

Compound 4, half-maximal inhibitory concentration: 38700 nM
Beside the measured number, compound 4's estimate is 1.9-fold (0.29 log units) below it; the measured number falls inside the stated range.
By their numbers in this assay, from the lowest: compound 2; then compounds 3 and 4 (each within the scatter of the next); then compound 1.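

In this assay, among these compounds, the exchange of 1-methyl-2-phenylethenyl for (4-bromophenyl)amino on a carbonyl carbon gives a 1.1-fold higher number from compound 3 to compound 4 (0.03 log units; within the scatter), the only one-place comparison available here. At this position, the two groups cannot be told apart in this assay, even though one carries a double bond outside aromatic rings and the other a bromine and a hydrogen-bond donor. Nothing measured here bears on the reason for this result. From the compounds shown here alone, whether a simple amine or a carboxylic acid on this carbonyl carbon would give a number separable from these two remains open.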